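Compound 1 to compound 4: swapping the ether-linked aryl group

This account rests on a few compounds, and the source may have more. Where it says the series, first, only, none or still open, it means among the compounds named here.

Measured in an ADME assay on microsomes from liver (Rattus norvegicus) for metabolic stability; a lower number here means slower removal, a higher number faster removal of the compound:
- compound 1 `N#Cc1ccccc1COc1ccc([C@H]2CC[C@@H](C(N)=O)N2)cc1`: 1.4 mL.min-1.g-1
- compound 2 `N#Cc1cc([C@H]2CC[C@@H](C(N)=O)N2)ccc1OCc1ccccc1F`: 2 mL.min-1.g-1
- compound 3 `NC(=O)[C@@H]1CC[C@H](c2ccc(OCc3ccccc3F)cn2)N1`: 0.6 mL.min-1.g-1

Compound 1 stands within the scatter of compound 2, while compound 3 gives a lower number, beyond the scatter.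

Compound 4 `NC(=O)[C@@H]1CC[C@H](c2ccc(OCc3cccc(F)c3)cc2)N1` has 3-fluorophenyl in place of 2-cyanophenyl on a saturated chain carbon bound to an oxygen on an aromatic ring. Going by the values given here, no measured pair isolates this change. The fluorine-bearing compounds offer only a loose guide: compound 2 gives 2 mL.min-1.g-1 and compound 3 gives 0.6 mL.min-1.g-1, and both also differ from compound 4 elsewhere in the structure. In this assay, a small upward change that stays within the scatter is expected, with an estimated step of a 1.3-fold higher number from compound 1 to compound 4 (0.11 log units; within the scatter). For compound 4 the estimate is 1.8 mL.min-1.g-1, with an expected range of 0.9 mL.min-1.g-1 to 3.6 mL.min-1.g-1.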

Compound 4, intrinsic clearance in microsomes: < 0.5 mL.min-1.g-1
Compound 4: a limit, no number (the forecaster's own chance of this, stated with the estimate: 5%); middle value at least 3.6-fold (0.55 log units) away from the limit.
By their numbers in this assay, from the lowest: compound 3; then compounds 1 and 2 (each within the scatter of the next). At a limit, below all of these: compound 4.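

In this assay, going by these compounds alone, the swap to 3-fluorophenyl in place of 2-cyanophenyl on a saturated chain carbon bound to an oxygen on an aromatic ring gives an at least 2.8-fold lower number from compound 1 to compound 4 (0.44 log units; beyond the scatter) and is the first step that changes one place only. It shows that this position alone can move the read-out beyond the scatter, and downward. Compound 4 gives < 0.5 mL.min-1.g-1, which is a limit of the assay and not a number, so only the smallest possible size of the step is known: the limit of < 0.5 mL.min-1.g-1 in this assay, at which 1 of the 4 values shown sits.

The swap changes both the substituent and where it sits, and the compounds shown do not separate the two. Plain phenyl or 3-cyanophenyl on the same core would show whether the loss of the nitrile or the gain of the fluorine carries the step.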